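The compounds below may be only part of what the source reports. "The series", "measured", "known", "first", "only" and "open" are said of these compounds alone.

Of the compounds shown here, three built on one shared core have been measured in a functional assay for inhibition of Thromboxane-A synthase (Homo sapiens); a lower number here means a stronger inhibitor, a higher number a weaker inhibitor. Compound 1 `COC(=O)c1ccc(COC(COCc2ccc(OC)cc2)Cn2ccnc2)cc1` gives 1260 nM. Compound 2 `CCCOC(=O)c1ccc(COC(COCc2ccc(OC)cc2)Cn2ccnc2)cc1` gives 180 nM. Compound 3 `COc1ccc(COCC(Cn2ccnc2)OCc2ccc(C(=O)OCc3ccccc3)cc2)cc1` gives 1490 nM; on the numbers, its nearest neighbour is compound 1, at a distance within the scatter, and the one furthest from it is compound 2, beyond the scatter. Of the measured steps, a 7.0-fold lower number from compound 1 to compound 2 (0.85 log units; beyond the scatter) and an 8.3-fold higher number from compound 2 to compound 3 (0.92 log units; beyond the scatter) lie beyond the scatter, while a 1.2-fold higher number from compound 1 to compound 3 (0.07 log units; within the scatter) stays within it.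

Compound 4 `COc1ccc(COCC(Cn2ccnc2)OCc2ccc(C(=O)N(C)C)cc2)cc1` differs from compound 3 in one place: dimethylamino in place of benzyloxy on a carbonyl carbon. For the measured compounds named here, none of the measured steps makes this exchange; each of them only varies the group on the saturated chain carbon bound to the oxygen next to the carbonyl group. Those steps show that the group on that side of the carbonyl moves the number by a modest amount at most, and that a small group there (compound 1) and a large one (compound 3) end within the scatter of each other. A small group enters in compound 4, so the expectation is a step of about a 1.2-fold lower number from compound 3 to compound 4 (0.09 log units; within the scatter), which may well stay within the scatter. Compound 4 is therefore estimated at 1200 nM, with a range from 400 nM to 4000 nM.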

Compound 4, half-maximal inhibitory concentration: 1940 nM
Estimate against measurement, compound 4: 1.6-fold (0.21 log units) below, and the stated range covers the measured number.
By their numbers in this assay, from the lowest: compound 2; then compounds 1, 3 and 4 (each within the scatter of the next).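

In this assay, replacing benzyloxy with dimethylamino on the carbonyl carbon gives a 1.3-fold higher number from compound 3 to compound 4 (0.11 log units; within the scatter), and replacing methoxy with it gives a 1.5-fold higher number from compound 1 to compound 4 (0.19 log units; within the scatter), so a group joined to that carbon through nitrogen rather than oxygen stays within the scatter of both. Propoxy is the group that stands apart, with an 11-fold higher number from compound 2 to compound 4 (1.03 log units; beyond the scatter), which adds a third group to the two that compound 2 already separated from itself and makes compound 2 the only one of the four set apart from the rest by a step beyond the scatter. Nothing measured here accounts for this separation of propoxy from methoxy, benzyloxy and dimethylamino.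

From the compounds shown here alone, it remains open whether the low number of compound 2 belongs to propoxy alone, or whether ethoxy, butoxy or a longer chain on the carbonyl carbon would share it. Going by these compounds, it is equally open whether a dipropylamino group or a carboxylic acid in that place would fall with propoxy or with dimethylamino.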